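This account rests on a few compounds, and the source may have more. Where it says the series, first, only, none or still open, it means among the compounds named here.

In an in vitro ADME assay on microsomes from liver (Homo sapiens) for pharmacokinetics, read by LC-MS, with a stated time of 10 min, tested at 1 uM (on this read-out higher numbers stand for fast clearance and lower numbers for slow clearance), compound 2 `CN1C[C@H](C(=O)Nc2ccc(C3CC3)cc2)[C@@H](c2ccc(/C=C/C(=O)Nc3ccccc3N)cc2)C1` gives 12 mL/min/kg, which is the second highest of the three numbers seen so far and within the usual scatter of both neighbours. Compound 3 `CN1C[C@H](C(=O)Nc2cccnc2)[C@@H](c2ccc(/C=C/C(=O)Nc3ccccc3N)cc2)C1` gives 10 mL/min/kg and compound 1 `Cc1ccc(NC(=O)[C@H]2CN(C)C[C@@H]2c2ccc(/C=C/C(=O)Nc3ccccc3N)cc2)cc1` gives 15 mL/min/kg. Compound 4 `CN1C[C@H](C(=O)N2CCCCC2)[C@@H](c2ccc(/C=C/C(=O)Nc3ccccc3N)cc2)C1` differs from compound 2 in one place: piperidin-1-yl in place of (4-cyclopropylphenyl)amino on a carbonyl carbon. The steps measured among the first three compounds were all small: a 1.3-fold lower number from compound 1 to compound 2 (0.10 log units; within the scatter), a 1.5-fold lower number from compound 1 to compound 3 (0.18 log units; within the scatter) and a 1.2-fold lower number from compound 2 to compound 3 (0.08 log units; within the scatter). None of them exchanges the amide partner for piperidin-1-yl, so they bear on the new change only loosely, and no step beyond the scatter is expected in this assay; the expected step is no change at the digits printed from compound 2 to compound 4 (within the scatter). Compound 4 is therefore estimated at 12 mL/min/kg, with a range from 6 mL/min/kg to 25 mL/min/kg.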

Compound 4, clearance: 9 mL/min/kg
The estimate for compound 4 lay 1.3-fold (0.12 log units) above the measured number, within the range that was stated.
By their numbers in this assay, from the lowest: compounds 4, 3, 2 and 1 (each within the scatter of the next).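

In this assay, piperidin-1-yl on the carbonyl carbon gives a 1.3-fold lower number from compound 2 to compound 4 (0.12 log units; within the scatter) and a 1.1-fold lower number from compound 3 to compound 4 (0.05 log units; within the scatter) and a 1.7-fold lower number from compound 1 to compound 4 (0.22 log units; within the scatter) and all three steps lie within the scatter. So, among these four compounds, this read-out stays within the scatter even when the aromatic ring and the amide hydrogen of the (4-cyclopropylphenyl)amino group are gone. No evidence is available to explain this result. Still open, as far as these compounds go, is whether a morpholine ring or an open-chain dimethylamino group on this carbonyl carbon would also stay within the scatter.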